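Methoxy to isopropoxy: expected outcome for compound 3

This account rests on a few compounds, and the source may have more. Where it says the series, first, only, none or still open, it means among the compounds named here.

Measured so far in a functional assay on aorta with Voltage-dependent L-type calcium channel subunit alpha-1C (Oryctolagus cuniculus) as the target; on this read-out lower numbers stand for stronger inhibition and higher numbers for weaker inhibition:
- compound 1 `CO/C(O)=C1\C(C)=NC(C)=C(C(=O)OCN2C(=O)c3ccccc3S2(=O)=O)C1c1cccc([N+](=O)[O-])c1`: 15.1 nM
- compound 2 `CO/C(O)=C1\C(C)=NC(C)=C(C(=O)OCN2C(=O)c3ccccc3S2(=O)=O)C1c1ccccc1[N+](=O)[O-]`: 30.9 nM

Compound 2 holds the higher of the two numbers in this assay; its nearest neighbour is compound 1, and the change between them is a 2.0-fold higher number from compound 1 to compound 2 (0.31 log units; beyond the scatter), a swap of the nitrophenyl position on a saturated ring carbon.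

Compound 3 `CC1=NC(C)=C(C(=O)OCN2C(=O)c3ccccc3S2(=O)=O)C(c2ccccc2[N+](=O)[O-])/C1=C(\O)OC(C)C` differs from compound 2 only at the alkoxy group: isopropyl in place of methyl on an oxygen on an unsaturated carbon. Going by the values given here, no measured pair in this set varies the alkoxy group, so the one recorded step, the nitrophenyl swap, does not bear on this change. There is nothing in the data to set a direction, and the working expectation is a step within the scatter, centred on the value of compound 2, with wide bounds to reflect the absence of a precedent.

The expected step is a 1.0-fold higher number from compound 2 to compound 3 (0.00 log units; within the scatter). Compound 3 is therefore estimated at 31 nM, with a range from 10 nM to 95 nM.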

Compound 3, half-maximal inhibitory concentration: 1.4 nM
For compound 3 the middle estimate is 22-fold (1.35 log units) above the measured one; measured number below the stated range.
By their numbers in this assay, from the lowest: compound 3; then compound 1; then compound 2.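

In this assay the alkoxy group on the unsaturated carbon emerges as a position that strongly moves the read-out: isopropyl in place of methyl gives a 22-fold lower number from compound 2 to compound 3 (1.34 log units; beyond the scatter) and so stronger inhibition. Going by these compounds alone, the earlier pair varied only the nitrophenyl position and showed a modest change, a 2.0-fold higher number from compound 1 to compound 2 (0.31 log units; beyond the scatter) so this is the first indication that the alkoxy group matters more, and that the larger isopropoxy is accepted here with the 2-nitrophenyl group in place. No measured evidence on the origin of this gain is available.

On these data alone, whether the gain continues with a longer chain such as n-butoxy, or with a benzyl group on the oxygen, remains open. Also open, as far as these compounds go, is whether isopropoxy gives a step of similar size on the 3-nitrophenyl compound 1.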